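The compounds below may be only part of what the source reports. "The series", "measured", "known", "first", "only" and "open" are said of these compounds alone.

Measured so far:
compound 1 `COc1ccc(-c2[nH]c3ccccc3c2/C=C(\C#N)S(=O)(=O)c2ccccc2)cc1` — in a functional assay on K562 cells (Homo sapiens) for inhibition, read by sulforhodamine B assay, with a stated time of 48 h (a higher number here means a weaker inhibitor of growth, a lower number a stronger inhibitor of growth), compound 1 gives 535 nM
compound 2 `COc1ccc2[nH]c(-c3ccccc3)c(C=C(C#N)C#N)c2c1` — in this assay compound 2 gives 2100 nM

Compound 1 holds the lowest of the two numbers; compound 2 shows a higher number, and the gap between them lies beyond the scatter. The two differ at more than one place, so no single step can be read from their comparison.

Compound 3 `COc1ccc(-c2[nH]c3ccc(OC)cc3c2/C=C(\C#N)S(=O)(=O)c2ccccc2)cc1` has not yet been measured. It differs from compound 1 in one place: methoxy in place of hydrogen on an aromatic carbon. Going by the values given here, no pair of measured compounds shows this change alone, so its effect in this assay has no precedent here. Compound 2 also carries a methoxy group, but its further differences from compound 1 rule out reading a step from it. The step from compound 1 to compound 3 is expected to be small, of no size beyond the scatter, with the range widened for lack of a precedent: a 1.1-fold higher number from compound 1 to compound 3 (0.05 log units; within the scatter) is the expected step. For compound 3 the estimate in this assay is 600 nM, between 200 nM and 1800 nM.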

Compound 3, concentration for 50% growth inhibition: 508 nM
The estimate for compound 3 lay 1.2-fold (0.07 log units) above the measured number, within the range that was stated.
By their numbers in this assay, from the lowest: compounds 3 and 1 (each within the scatter of the next); then compound 2.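

In this assay, going by these compounds alone, methoxy in place of hydrogen on an aromatic carbon of the six-membered carbon ring, meta to a fused ring and para to a fused ring, gives a 1.1-fold lower number from compound 1 to compound 3 (0.02 log units; within the scatter) as the first step that can be read at a single place. This position therefore accepts a methoxy group with no change in the number beyond the scatter, which the comparison of compound 1 with compound 2 could not show. No measurement shown here accounts for this result.

As far as these compounds go, whether this position accepts other groups, such as an amine, a carboxylic acid or a longer alkoxy chain, remains open. Also open, from the compounds shown here alone, is whether methoxy on other aromatic carbons of the shared core gives a step of similar size.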